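Replacing hydroxy with pyrrolidin-1-yl on a saturated ring carbon

The source may report more compounds than this note shows. Statements on the series, on what has been measured and on what is new or still open speak of the compounds shown alone.

In an ADME assay on microsomes from liver (Homo sapiens) for pharmacokinetics, read by LC-MS, with a stated time of 60 min, tested at 1 uM (on this read-out lower numbers stand for slow clearance and higher numbers for fast clearance), compound 1 (`CCCn1cc(S(=O)(=O)c2ccc(CNC(=O)N3Cc4ccncc4C3)cc2)cn1`) gives 11 mL/min/kg and compound 2 (`O=C(NCc1ccc(S(=O)(=O)N2CCC(O)CC2)cc1)N1Cc2ccncc2C1`) gives 6 mL/min/kg, so compound 2 stands within the scatter of compound 1. Going by the values given here, the one measured step is a 1.8-fold lower number from compound 1 to compound 2 (0.26 log units; within the scatter), and it brings 4-hydroxypiperidin-1-yl in place of 1-propyl-1H-pyrazol-4-yl on a sulfonyl sulfur. Compound 3 (`O=C(NCc1ccc(S(=O)(=O)N2CCC(N3CCCC3)CC2)cc1)N1Cc2ccncc2C1`) instead carries pyrrolidin-1-yl in place of hydroxy on a saturated ring carbon. Among the compounds with values here, no measured step changes this position alone, so the step on the sulfonyl sulfur is only a loose guide. Starting from compound 2 at 6 mL/min/kg, no change beyond the scatter is expected, and the direction remains open. The estimated step is a 1.3-fold higher number from compound 2 to compound 3 (0.12 log units; within the scatter). For compound 3 the expected value is 8 mL/min/kg, with an estimated range from 3.5 mL/min/kg to 18 mL/min/kg.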

Compound 3, clearance: 6 mL/min/kg
Compound 3: the middle estimate sits 1.3-fold (0.12 log units) above what was measured; low and high end bracket the measured number.
By their numbers in this assay, from the lowest: compounds 2, 3 and 1 (each within the scatter of the next).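

Going by these compounds alone, at this saturated ring carbon, this assay now gives a direct reading of the change itself, where the earlier compounds offered only a loose guide: the step is no change at the digits printed from compound 2 to compound 3 (within the scatter), so pyrrolidin-1-yl, with its five heavy atoms and one ring, takes the place of hydroxy without a shift beyond the scatter. The step on the sulfonyl sulfur, with 4-(pyrrolidin-1-yl)piperidin-1-yl in place of 1-propyl-1H-pyrazol-4-yl, is a 1.8-fold lower number from compound 1 to compound 3 (0.26 log units; within the scatter), so this larger group also leaves the read-out within the scatter of the pyrazole compound. Nothing given here bears on what lies behind these readings.

As far as these compounds go, whether a carboxylic acid or an open-chain amine such as dimethylamino on this ring carbon would read the same stays open. So does what a longer chain there would give.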